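This account rests on a few compounds, and the source may have more. Where it says the series, first, only, none or still open, it means among the compounds named here.

Measured in an assay (strain Holtzman-Sprague-Dawley) for inhibition of 3-hydroxy-3-methylglutaryl-coenzyme A reductase (Rattus norvegicus), with a stated time of 30 min; on this read-out lower numbers stand for stronger inhibition and higher numbers for weaker inhibition:
compound 1, `O=C1C[C@H](O)C[C@@H](/C=C/c2cnc3c(F)c(F)c(F)cc3c2Sc2ccc(F)cc2)O1`: 7930 nM
compound 2, `O=C1C[C@H](O)C[C@@H](/C=C/c2cnc3cc(Sc4ccc(F)cc4)c(F)cc3c2Sc2ccc(F)cc2)O1`: 38900 nM
compound 3, `O=C1C[C@H](O)C[C@@H](/C=C/c2cnc3c(F)c(F)c(F)cc3c2Sc2ccccc2)O1`: 10700 nM

Compound 3 stands second highest of the three numbers in this assay. Its nearest neighbour is compound 1, and the step of a 1.3-fold higher number from compound 1 to compound 3 (0.13 log units; within the scatter) lies within the scatter. Compound 2 gives the higher number, beyond the scatter from compound 3. Compound 4, `CC(C)c1ccc(Sc2c(/C=C/[C@@H]3C[C@@H](O)CC(=O)O3)cnc3c(F)c(F)c(F)cc23)cc1`, differs from compound 3 by isopropyl in place of hydrogen on an aromatic carbon. Among the measured compounds shown here, no measured step touches this part of the structure; the only single change on record, from compound 1 to compound 3, sits on the same ring but swaps a different group and stayed within the scatter. For compound 4 a step of a 1.2-fold lower number from compound 3 to compound 4 (0.08 log units; within the scatter) is therefore expected, not beyond the scatter. Compound 4 is estimated at 9000 nM, between 2500 nM and 30000 nM.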

Compound 4, half-maximal inhibitory concentration: 3210 nM
The estimate for compound 4 lay 2.8-fold (0.45 log units) above the measured number; the range from low to high includes it.
By their numbers in this assay, from the lowest: compound 4; then compounds 1 and 3 (each within the scatter of the next); then compound 2.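

In this assay, changing phenylsulfanyl to (4-isopropylphenyl)sulfanyl gives a 3.3-fold lower number from compound 3 to compound 4 (0.52 log units; beyond the scatter), so this position, where swapping fluoro and hydrogen had stayed within the scatter, can shift the read-out. Isopropyl in place of fluoro at the same carbon likewise gives a 2.5-fold lower number from compound 1 to compound 4 (0.39 log units; beyond the scatter). No measurement at hand explains why isopropyl lowers the number. The compounds shown leave open whether a longer chain, a tert-butyl group or an amine on this carbon would lower the number further.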